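The source may report more compounds than this note shows. Statements on the series, on what has been measured and on what is new or still open speak of the compounds shown alone.

Compound 1 `COc1ccc([C@@H]2C/C(=N/OCc3cn(-c4ccc(O)cc4)nn3)c3cc(CC=C(C)C)c(OC)cc3O2)cc1` gives 63% in a functional assay on MCF7 cells (Homo sapiens) for inhibition, read by sulforhodamine B assay, with a stated time of 48 h, tested at 50 uM (a higher number here means more inhibition of growth at the concentration tested, a lower number less inhibition of growth), and stands lowest of the three numbers in hand. Compound 2 `COc1cc2c(cc1CC1OC1(C)C)C(=O)C[C@@H](c1ccc(O)cc1)O2` at 98% and compound 3 `COc1cc2c(cc1CC=C(C)C)/C(=N/NC(N)=O)C[C@@H](c1ccc(O)cc1)O2` at 93% both lie beyond the scatter above compound 1. For the measured compounds named here, neither differs from compound 1 in one place only, so no measured step calibrates the next change. Compound 4 `COc1ccc([C@@H]2C/C(=N/OCc3cn(-c4ccc(NC(C)=O)cc4)nn3)c3cc(CC=C(C)C)c(OC)cc3O2)cc1` carries acetamido in place of hydroxy on an aromatic carbon, para to a large group, with acetamido in place of hydroxy on an aromatic carbon as the counted difference. No step beyond the scatter is expected in this assay and any drift is expected to be slightly downward. The estimated change is a number 3 percentage points lower from compound 1 to compound 4 (within the scatter) on this reading. For compound 4 the expected value is 60% with an estimated range from 40% to 80% for now.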

Compound 4, percent growth inhibition at one concentration: 0%
Compound 4: the middle estimate sits 60 percentage points above what was measured; measured number below the stated range.
By their numbers in this assay, from the lowest: compound 4; then compound 1; then compounds 3 and 2 (each within the scatter of the next).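

In this assay, for the compounds shown here, the hydroxy-to-acetamido change, on the aromatic carbon para to a large group, gives the first single-place step, a number 63 percentage points lower from compound 1 to compound 4 (beyond the scatter) and so shows that this position is not silent. Hydroxy and acetamido carry the same counted hydrogen-bond donors and acceptors and differ in heavy atoms, so those counts do not track the step. Nothing measured here explains it.

As far as these compounds go, whether the step follows the loss of hydroxy or the arrival of acetamido stays open. A plain amine or a methoxy on the same carbon would separate the two readings.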